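Extending the Side Chain in a Pyridinone Cell-Growth Series

This account rests on a few compounds, and the source may have more. Where it says the series, first, only, none or still open, it means among the compounds named here.

For the measured compounds named here, compound 2, with the structure `CCOc1cc(=O)n(CCCO)c2c1CC(CC=C(C)C)C(C)(C)C2`, stands highest of the two compounds measured so far. In a functional assay on PANC-1 cells (Homo sapiens) for inhibition, read by MTT assay, with a stated time of 24 h, tested at 10 uM (a lower number here means less inhibition, a higher number more inhibition at the concentration tested (going by the name of the read-out)), compound 2 gives 66.5%. Its nearest neighbour, compound 1, structure `CC(C)=CCC/C(C)=C/CC1Cc2c(O)cc(=O)n(CCCO)c2CC1(C)C`, differs from it in two places at once and gives 28.7% in this assay, a gap that lies beyond the usual scatter. The two measured compounds differ in more than one place. No single step can be read from them.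

Compound 3, structure `CCOc1cc(=O)n(CCCO)c2c1CC(C/C=C(\C)CCC=C(C)C)C(C)(C)C2`, is the next compound to be measured. Relative to compound 2 the change is 3-methylbut-2-en-1-yl in place of hydrogen on a saturated chain carbon bound to a double-bonded chain carbon. The longer chain of compound 3 is also present in compound 1, whose value 28.7% is the lower of the two, so a downward step is expected, though its size is uncertain. The expected step is a number 18.5 percentage points lower from compound 2 to compound 3 (beyond the scatter). Compound 3 is estimated at 48%, with a likely range from 25% to 72%.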

Compound 3, a percentage reported as inhibition, at one concentration (the size of the read-out at that concentration, not a potency): 67.8%
Compound 3: middle estimate off by 19.8 percentage points, on the low side; the measured number falls inside the stated range.
By their numbers in this assay, from the lowest: compound 1; then compounds 2 and 3 (each within the scatter of the next).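

In this assay, 3-methylbut-2-en-1-yl in place of hydrogen on a saturated chain carbon bound to a double-bonded chain carbon gives a number 1.3 percentage points higher from compound 2 to compound 3 (within the scatter) so, with ethyl on the oxygen, lengthening the chain to 3,7-dimethylocta-2,6-dien-1-yl leaves the inhibition unchanged within the scatter. With that longer chain in both compounds, ethyl in place of hydrogen on an oxygen on an aromatic ring gives a number 39.1 percentage points higher from compound 1 to compound 3 (beyond the scatter) and this large step shows that the ethyl group alone separates the two compounds. Nothing measured here explains why either step has its size.

On these data alone, it remains open whether a longer chain than 3,7-dimethylocta-2,6-dien-1-yl, or an amine or a carboxylic acid in its place, would keep this level of inhibition. As far as these compounds go, it is also open whether methyl or propyl on that oxygen would match ethyl.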